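Alkyl chain trimming on the squaramide-type series

This account rests on a few compounds, and the source may have more. Where it says the series, first, only, none or still open, it means among the compounds named here.

Measured so far:
compound 1, `CC[C@H](C)/N=c1\c(O)c(O)\c1=N/Cc1ccc(C#N)cc1`: 2200 nM
compound 2, `CCC(C)(C)/N=c1\c(O)c(O)\c1=N/Cc1c(C)cccc1Cl`: 4400 nM
compound 3, `CCc1cc(C#N)ccc1C/N=c1\c(O)c(O)\c1=N/C(C)(C)CC`: 110 nM

In a functional assay for inhibition, with Rattus norvegicus as the target (on this read-out lower numbers stand for stronger inhibition and higher numbers for weaker inhibition), compound 1 gives 2200 nM, the second highest of the three numbers. Compound 2 sits close by with 4400 nM, a gap within the usual scatter, so no order is read between the two. Going by the values given here, compound 3 stands apart with 110 nM, a gap beyond the scatter; it differs from compound 1 in more than one place, so no single step is drawn from it.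

Compound 4, `CCC/N=c1\c(O)c(O)\c1=N/Cc1ccc(C#N)cc1`, is not yet measured. It differs from compound 1 by hydrogen in place of methyl on a saturated chain carbon bound to a double-bonded nitrogen and a saturated chain carbon. Among the compounds with values here, no step between measured compounds isolates this change, and compound 3 pairs its larger alkyl group with a different aryl part, so the effect of trimming the chain is not pinned down. The expectation is a small loss, near the edge of the scatter: the step of a 1.8-fold higher number from compound 1 to compound 4 (0.26 log units; within the scatter) is the estimate. Compound 4 is thus expected to give about 4000 nM, within 1500 nM to 12000 nM.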

Compound 4, half-maximal inhibitory concentration: 21900 nM
Compound 4: the middle estimate sits 5.5-fold (0.74 log units) below what was measured; measured number outside the range, above it.
By their numbers in this assay, from the lowest: compound 3; then compounds 1 and 2 (each within the scatter of the next); then compound 4.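

Going from sec-butyl to propyl gives a 10-fold higher number from compound 1 to compound 4 (1.00 log units; beyond the scatter) in this assay, the first step in the series that isolates a single place. This position is therefore not indifferent to the change: with the rest of compound 1 unchanged, losing one methyl on a saturated chain carbon bound to a double-bonded nitrogen and a saturated chain carbon is enough for a step beyond the scatter. No measurement shown gives a reason for this step.

Open, as far as these compounds go, is whether a longer chain, a cyclopropyl group or a hydroxyl group at this position would hold or shift the number of compound 1, and how the opposite configuration at that carbon would read. Also open, from the compounds shown here alone, is whether the step carries over to the different aryl parts of compound 2 and compound 3.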